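A few compounds are considered here, and "the series" means these few. Any claim that something is new, unique, unknown or untested is made for them only; others in the source may bear on it.

Compound 1 `CCC1=C(O)c2c(oc(-c3ccc(OC)cc3)cc2=O)C(CC)(CC)C1=O` gives 0.68 uM in a functional assay on KBVIN cells (Homo sapiens) for antiproliferative activity, read by sulforhodamine B assay, with a stated time of 3 days; a higher number here means that more compound is needed for the effect, a lower number that less compound is needed.
Compound 2 `CCC1=C(O)c2c(oc(-c3cccc(C)c3)cc2=O)C(CC)(CC)C1=O` gives 3.69 uM in this assay.
Compound 3 `CCC1=C(O)c2c(oc(-c3ccccc3F)cc2=O)C(CC)(CC)C1=O` gives 3.93 uM in this assay.

Compound 3 has the highest number of the three; compound 2 is within the scatter of it, while compound 1 needs far less material, as the step of a 5.8-fold higher number from compound 1 to compound 3 (0.76 log units; beyond the scatter) shows. Compound 4 `CCC1=C(O)c2c(oc(-c3ccc(OC)c(F)c3)cc2=O)C(CC)(CC)C1=O` has not yet been measured. The change from compound 3 is 3-fluoro-4-methoxyphenyl in place of 2-fluorophenyl on an aromatic carbon. The measured steps that bear on this are a 5.8-fold higher number from compound 1 to compound 3 (0.76 log units; beyond the scatter) and a 5.4-fold higher number from compound 1 to compound 2 (0.73 log units; beyond the scatter): both times the 4-methoxyphenyl of compound 1 was exchanged for a ring without the methoxy group, and both times the number rose by a modest amount, beyond the scatter. The step of a 1.1-fold higher number from compound 2 to compound 3 (0.03 log units; within the scatter) shows that swapping 3-methylphenyl for 2-fluorophenyl changed little. Compound 4 brings the 4-methoxy group back, with a fluorine added on the same ring. On the strength of compound 1 and its value 0.68 uM, the expected direction is a lower number, with the expected step of a 3.9-fold lower number from compound 3 to compound 4 (0.59 log units; beyond the scatter). For compound 4 the estimated value in this assay is 1 uM, with a range from 0.4 uM to 2.5 uM.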

Compound 4, concentration for half-maximal effect: 0.1 uM
Compound 4: the middle estimate sits 10-fold (1.00 log units) above what was measured, and the stated range ends above it.
By their numbers in this assay, from the lowest: compound 4; then compound 1; then compounds 2 and 3 (each within the scatter of the next).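

For the compounds shown here, the one-place change that isolates the fluorine is the step from the 4-methoxyphenyl to the 3-fluoro-4-methoxyphenyl ring in this assay (a 6.8-fold lower number from compound 1 to compound 4 (0.83 log units; beyond the scatter)), so the ring that gave the lowest number among the earlier compounds still had room to go lower. Going by these compounds alone, the larger steps (a 39-fold lower number from compound 3 to compound 4 (1.59 log units; beyond the scatter)) and (a 37-fold lower number from compound 2 to compound 4 (1.57 log units; beyond the scatter)) show that the choice of ring at this position spans a much wider range than the earlier compounds revealed. A fluorine alone does not guarantee a low number, however, since compound 3 also carries one, in its 2-fluorophenyl ring, and has one of the two highest numbers; no measurement shown explains why the added fluorine lowers the number in compound 4.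

The compounds shown leave open whether the fluorine would lower the number on a phenyl ring without the methoxy group, and so whether the gain depends on having both groups together. They also leave open whether a chlorine, a hydroxyl or an amine in place of that fluorine would give a similar result.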